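Trading a large heteroaryl group for a single iodine

A few compounds are considered here, and "the series" means these few. Any claim that something is new, unique, unknown or untested is made for them only; others in the source may bear on it.

Of the compounds shown here, three from this study share one core and have been measured in an assay for inhibition of Fatty-acid amide hydrolase 1 (Rattus norvegicus); on this read-out higher numbers stand for weaker inhibition and lower numbers for stronger inhibition. Compound 1 `COC(=O)c1cc(-c2cnc(C(=O)CCc3ccc(-c4ccccc4)cc3)o2)ccn1` gives 1.5 nM. Compound 2 `O=C(CCc1ccc(COc2ccccc2)cc1)c1ncc(-c2cccc(-c3nnn[nH]3)n2)o1` gives 21 nM, and compound 3 `O=C(CCc1ccc(-c2ccccc2)cc1)c1ncc(-c2cccc(-c3nnn[nH]3)n2)o1` gives 25 nM. For the measured compounds named here, compound 2 thus stands second highest of the three numbers: its gap to compound 1 is beyond the scatter, while its gap to compound 3 is within it, and the one step between neighbours, a 1.2-fold higher number from compound 2 to compound 3 (0.08 log units; within the scatter), changes nothing meaningful.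

Compound 4 `O=C(CCc1ccc(COc2ccccc2)cc1)c1ncc(I)o1` is not yet measured. It differs from compound 2 in one place: iodo in place of 6-(1H-tetrazol-5-yl)pyridin-2-yl on an aromatic carbon. Going by the values given here, no measured step touches this part of the molecule; the step from compound 2 to compound 3 alters the far end of the chain and so says nothing about it. Among the compounds with values here, the only guide is that all three measured compounds keep a substituted pyridine at this position and all bind strongly. Removing that whole group and leaving a lone iodine is a large change, and a weaker inhibition, a higher number, is expected. Compound 4 is therefore estimated at 300 nM, with a plausible range from 60 nM to 1500 nM, meaning an expected step of a 14-fold higher number from compound 2 to compound 4 (1.15 log units; beyond the scatter).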

Compound 4, inhibition constant: 4 nM
Compound 4: the middle estimate sits 75-fold (1.88 log units) above what was measured; the whole stated range lies above it.
By their numbers in this assay, from the lowest: compound 1; then compound 4; then compounds 2 and 3 (each within the scatter of the next).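

In this assay, iodo in place of 6-(1H-tetrazol-5-yl)pyridin-2-yl gives a 5.3-fold lower number from compound 2 to compound 4 (0.72 log units; beyond the scatter), a modest step but one that lies beyond the usual scatter. All three earlier compounds carry a substituted pyridine at this carbon, next to the ring oxygen, so they could not show whether strong inhibition depends on having such a group there; this pair shows that, with the phenoxymethyl end held constant, the two-ring group can leave and a single atom with no ring, no hydrogen-bond donors and no hydrogen-bond acceptors can take its place without any loss. The data at hand offer no explanation for why the lone iodine gives the lower number.

As far as these compounds go, it stays open whether iodine itself matters or whether simply losing the large group is enough, a question that plain hydrogen, chlorine or bromine at this carbon would address. From the compounds shown here alone, it is also open whether a small nitrile or carboxylic acid here would match iodine, and whether the same exchange would hold with the phenyl end of compound 3.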